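Aryl ether series: methylsulfanyl in place of chloro

The compounds below may be only part of what the source reports. "The series", "measured", "known", "first", "only" and "open" are said of these compounds alone.

Compound 1 `CNC[C@]1(O)Cc2ccccc2[C@@H]1Oc1ccccc1Cl` and compound 2 `CNC[C@]1(O)Cc2ccccc2[C@@H]1Oc1cccc(F)c1C` share one core and differ only in the substitution of the aryl ether ring. In an in vitro assay on HEK293 cells for inhibition of sodium-dependent dopamine transporter (Homo sapiens) (on this read-out higher numbers stand for weaker inhibition and lower numbers for stronger inhibition), compound 1 gives 10000 nM, the higher of the two numbers recorded so far. In this assay compound 2 gives 3000 nM, a number that lies beyond the scatter from that of compound 1. Within the data shown here, no step between measured compounds that differ in a single place is available, so the next change has no measured precedent within this set.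

Compound 3 `CNC[C@]1(O)Cc2ccccc2[C@@H]1Oc1ccccc1SC` differs from compound 1 by methylsulfanyl in place of chloro on an aromatic carbon of a six-membered aromatic ring of carbon only. With no comparable measured change to rest on, the step that this estimate means, a 1.7-fold lower number from compound 1 to compound 3 (0.22 log units; within the scatter), is expected to be small, toward a lower number, and not clearly beyond the scatter. Compound 3 is therefore expected to give around 6000 nM in this assay, with a range from 2000 nM to 20000 nM.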

Compound 3, half-maximal inhibitory concentration: > 10000 nM
Compound 3 ended at the assay's limit; the forecaster's own chance of this, stated with the estimate: 20%; at least 1.6-fold (0.22 log units) between middle value and limit.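

In this assay compound 3 gives > 10000 nM, which is a limit of the assay and not a number. Methylsulfanyl in place of chloro on an aromatic carbon, ortho to a large group, is the first single-place change in the series, and it gives a number no lower from compound 1 to compound 3 (the limit leaves the size open), so at this position the exchange brings no measurable move toward stronger inhibition. The size of this step cannot be read, because the value of compound 3 stands at the end of the range that can be read out: the limit of > 10000 nM in this assay, at which 1 of the 3 values shown sits.

From the compounds shown here alone, whether methylsulfanyl leaves inhibition unchanged or weakens it relative to chloro stays open, as the limit allows either reading in this assay. Also open, going by these compounds, is how a methoxy group, a nitrile or a primary amine would read at this same aromatic carbon, and whether methylsulfanyl would behave the same way on an aryl ether ring that carries a second substituent.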